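The source may hold more compounds than are shown below. What is called first, only, known or untested is meant among the compounds shown, and "the series" means these compounds.

The measured compounds and their values:

Compound 1 `Fc1cccc(F)c1Cc1cnc(Nc2ccc(CCOc3ccncc3)cc2)o1` gives 11000 nM in an ADME assay on MT2 cells (Homo sapiens) for cytotoxicity, read by MTT assay; a lower number here means that less compound is tolerated, a higher number that more compound is tolerated.
Compound 3 `Clc1cccc(Cl)c1Cc1nnc(Nc2ccc(COCc3ccco3)cc2)o1` gives 12000 nM.
Compound 2 `Clc1cccc(Cl)c1Cc1nnc(Nc2ccc(COCc3ccccn3)cc2)o1` gives only a limit of the assay, > 100000 nM.

Of the two numbers, compound 1 is the lowest, and compound 3 lies within the scatter of it. Compound 4 `Fc1cccc(F)c1Cc1cnc(Nc2ccc(Oc3cccnc3)cc2)o1` differs from compound 1 by (pyridin-3-yl)oxy in place of 2-((pyridin-4-yl)oxy)ethyl on an aromatic carbon. Within the data shown here, the only measured step, an at least 8.3-fold lower number from compound 2 to compound 3 (0.92 log units; beyond the scatter), concerns another exchange at another place and does not bear on this change. Among the measured compounds shown here, no measured step therefore speaks for a shift in this assay beyond the scatter in either direction. Compound 4 is expected to give 11000 nM, in a range from 4000 nM to 40000 nM, which is an expected step of no change at the digits printed from compound 1 to compound 4 (within the scatter).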

Compound 4, half-maximal cytotoxic concentration: 22000 nM
Beside the measured number, compound 4's estimate is 2.0-fold (0.30 log units) below it; measured number inside the range.
By their numbers in this assay, from the lowest: compounds 1, 3 and 4 (each within the scatter of the next). At a limit, above all of these: compound 2.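

In this assay, putting (pyridin-3-yl)oxy in place of 2-((pyridin-4-yl)oxy)ethyl on the aromatic carbon gives a 2.0-fold higher number from compound 1 to compound 4 (0.30 log units; within the scatter). This position therefore tolerates an exchange that removes the ethyl chain and moves the ring attachment together, with no shift beyond the scatter. Nothing available bears on why the two compounds stand so close.

Among these compounds, the single step does not separate the chain from the ring attachment. Going by these compounds, whether an amine or a carboxylic acid on this aromatic carbon would shift the number beyond the scatter also stays open.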